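From an acid to an amide on the shared core

This account rests on a few compounds, and the source may have more. Where it says the series, first, only, none or still open, it means among the compounds named here.

compound 1 `O=C(O)CCCc1ccc(NCc2cccc(Oc3ccccc3)c2)cc1` — 59%
compound 2 `Cc1nc(-c2ccc(C(F)(F)F)cc2)sc1CNc1ccc(CCC(N)=O)cc1` — 88%

Both were tested in a functional assay on CHO cells for agonist activity at Free fatty acid receptor 1 (Homo sapiens), read by a luciferase reporter; on this read-out higher numbers stand for larger maximal responses and lower numbers for smaller maximal responses. Compound 1 gives 59%, the lower of the two numbers; compound 2 gives 88%, a margin above compound 1 that goes beyond the usual scatter. The two compounds differ in more than one place, so that gap cannot be tied to a single change.

Compound 3 `CC(C)NC(=O)CCc1ccc(NCc2cccc(Oc3ccccc3)c2)cc1` has not yet been measured. It departs from compound 1 by one change: isopropylcarbamoyl in place of carboxymethyl on a saturated chain carbon, two bonds along the chain from an aromatic carbon. Compound 2 also carries a carbamoyl group where compound 1 has an acid, and compound 2 reaches 88%, which makes a rise plausible, but only a modest one. The step from compound 1 to compound 3 in this assay is expected to be a number 11 percentage points higher from compound 1 to compound 3 (beyond the scatter), at most just beyond the scatter. Compound 3 is therefore estimated to reach 70%, within a range from 45% to 95%.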

Compound 3, largest response reached (reported as percent of maximum), in percent of the reference or control that the assay uses: 66%
Compound 3: middle estimate off by 4 percentage points, on the high side; the range from low to high includes it.
By their numbers in this assay, from the lowest: compounds 1 and 3 (each within the scatter of the next); then compound 2.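

In this assay, putting isopropylcarbamoyl in place of carboxymethyl on a saturated chain carbon, two bonds along the chain from an aromatic carbon, gives a number 7 percentage points higher from compound 1 to compound 3 (within the scatter), so the two maximal responses cannot be told apart. On this core, then, a free carboxylic acid at this position is not required for a response of this size, and the entering group, with 6 heavy atoms against 4 and a nitrogen the acid lacks, is accepted here. Nothing measured here explains why the two responses match.

On these data alone, it remains open whether a primary amine or a sulfonamide at this position would give a similar response. Also open, as far as these compounds go, is whether a longer chain carrying the same isopropylcarbamoyl group would keep it.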